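Series notes: the step from compound 3 to compound 4

The compounds below may be only part of what the source reports. "The series", "measured", "known", "first", "only" and "open" are said of these compounds alone.

Values in an ADME assay on Huh-7 cells (Homo sapiens) for cytotoxicity, read by MTT assay, with a stated time of 72 h; on this read-out lower numbers stand for higher toxicity in this test and higher numbers for lower toxicity in this test:
- compound 1 (`COc1ccc(CNC(=O)/C=C/c2c[nH]c3ccccc23)cc1OC`) gives 89500 nM
- compound 2 (`CC(C)(C)c1ccc(NC(=O)CCc2c[nH]c3ccccc23)cc1`) gives 13600 nM
- compound 3 (`C/C(=C\c1c[nH]c2ccccc12)C(=O)O`) gives > 100000 nM, which is a limit and not a number

Compound 3 stands at the limit of > 100000 nM in this assay, at which 1 of the 3 values shown sits. Its entry is a limit of the assay, so any step away from it can be sized only loosely.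

Compound 4 (`C/C(=C\c1c[nH]c2ccccc12)C(=O)NCc1ccco1`) has ((furan-2-yl)methyl)amino in place of hydroxy on a carbonyl carbon. Among the measured compounds shown here, no step between measured compounds that differ in one place is available, so the expectation rests on indirect comparison. Compound 1 gives 89500 nM and compound 2 gives 13600 nM, and both carry a substituted amino group on the carbonyl carbon, as compound 4 does. Both also differ from compound 3 elsewhere, which weakens the comparison.

In this assay a modest move towards lower numbers is therefore expected, meaning somewhat higher toxicity in this test. The expected step is an at least 1.8-fold lower number from compound 3 to compound 4 (0.25 log units; that floor lies within the scatter). A result reported only as a limit remains quite possible. For compound 4 the estimated value is 55000 nM, with an expected range from 18000 nM to 100000 nM.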

Compound 4, half-maximal cytotoxic concentration: 39100 nM
Estimate against measurement, compound 4: 1.4-fold (0.15 log units) above; the range from low to high includes it.
By their numbers in this assay, from the lowest: compound 2; then compound 4; then compound 1. At a limit, above all of these: compound 3.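

Among the compounds shown here, until now no pair differing in one place was available, so nothing could be read directly at this position, a carbonyl carbon whose other neighbours are: double-bonded chain carbon. With ((furan-2-yl)methyl)amino in place of hydroxy, this assay now gives an at least 2.5-fold lower number from compound 3 to compound 4 (0.40 log units; beyond the scatter), so a change at this position alone moves the read-out towards higher toxicity in this test, and compound 4 gives a measured number of 39100 nM. Compound 3 has only a limit, so the true size of the step stays open and the printed size is only a floor: the limit of > 100000 nM in this assay, at which 1 of the 4 values shown sits.

This single step does not separate what the amide nitrogen contributes from what the five-membered aromatic ring contributes, and a plain methylamino group or an unsubstituted amino group on the same carbonyl carbon would be needed to draw that line. It also leaves open whether a benzylamino group or a longer chain between the nitrogen and the ring would give a number near that of compound 4 or a different one in this assay.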